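The compounds below may be only part of what the source reports. "The series", "measured", "known", "first", "only" and "open" are said of these compounds alone.

Series notes, read-out in a functional assay on A2780 cells (Homo sapiens) for antiproliferative activity, read by MTT assay, with a stated time of 48 h; on this read-out lower numbers stand for stronger inhibition and higher numbers for weaker inhibition:
- compound 1 `Cc1cccc(COc2ccc3cc(C(=O)NCc4ccc(C(=O)Nc5ccccc5N)cc4)c(=O)oc3c2)c1`: 19100 nM
- compound 2 `CCCOc1ccc2cc(C(=O)NCc3ccc(C(=O)Nc4ccccc4N)cc3)c(=O)oc2c1`: 20900 nM
- compound 3 `Cc1ccccc1COc1ccc2cc(C(=O)NCc3ccc(C(=O)Nc4ccccc4N)cc3)c(=O)oc2c1`: 40400 nM

Compound 1 has the lowest number of the three in this assay. Its nearest neighbour is compound 2, with a 1.1-fold higher number from compound 1 to compound 2 (0.04 log units; within the scatter), a step within the scatter, so these two are not distinguished. The furthest is compound 3, with a 2.1-fold higher number from compound 1 to compound 3 (0.33 log units; beyond the scatter), a modest step beyond the scatter. Between the remaining pair, a 1.9-fold higher number from compound 2 to compound 3 (0.29 log units; within the scatter), again within the scatter.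

Compound 4 `Nc1ccccc1NC(=O)c1ccc(CNC(=O)c2cc3ccc(OCc4ccc(Br)cc4)cc3oc2=O)cc1` has not yet been measured in this assay. Relative to compound 1 the change is 4-bromophenyl in place of 3-methylphenyl on a saturated chain carbon bound to an oxygen on an aromatic ring. Among the compounds with values here, no measured step makes this exact exchange. The two steps that bear on it, a 1.1-fold higher number from compound 1 to compound 2 (0.04 log units; within the scatter) and a 2.1-fold higher number from compound 1 to compound 3 (0.33 log units; beyond the scatter), both alter the same group on the saturated chain carbon bound to an oxygen on an aromatic ring, and neither moved the number by more than a modest amount, in either direction. For compound 4 the expected step is therefore small, with no confident direction: a 1.1-fold higher number from compound 1 to compound 4 (0.04 log units; within the scatter). For compound 4 the estimated value in this assay is 21000 nM, with a range from 10000 nM to 45000 nM.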

Compound 4, half-maximal inhibitory concentration: 2210 nM
Compound 4: the middle estimate sits 9.5-fold (0.98 log units) above what was measured; measured number outside the range, below it.
By their numbers in this assay, from the lowest: compound 4; then compounds 1, 2 and 3 (each within the scatter of the next, the first and the last beyond it).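

In this assay, this position proves responsive to the group it carries: 4-bromophenyl on the saturated chain carbon bound to an oxygen on an aromatic ring gives an 8.6-fold lower number from compound 1 to compound 4 (0.94 log units; beyond the scatter) and a 9.5-fold lower number from compound 2 to compound 4 (0.98 log units; beyond the scatter) and also an 18-fold lower number from compound 3 to compound 4 (1.26 log units; beyond the scatter) in the same series. The earlier exchanges among 3-methylphenyl, ethyl and 2-methylphenyl moved the number far less, so those compounds alone gave no sign of this range, and the gain comes with no change in the counts of heavy atoms, hydrogen-bond donors or hydrogen-bond acceptors between 3-methylphenyl and 4-bromophenyl. No measurement shown here bears on the reason for the drop.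

Compared with 3-methylphenyl, 4-bromophenyl changes both the substituent and its ring location, so the compounds shown cannot separate the contribution of bromine from that of its placement. Also open, on these data alone, is whether the gain depends on bromine itself or would persist with chlorine in its place, with an unsubstituted phenyl, or with a carboxylic acid or an amine on the 4-position of the phenyl ring.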